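The source may report more compounds than this note shows. Statements on the series, on what has been measured and on what is new or still open speak of the compounds shown alone.

Measured in an assay on isolated protein for displacement of a labelled ligand from 5-hydroxytryptamine receptor 6 (Homo sapiens), read by scintillation counting, with a stated time of 1 h; a lower number here means a stronger inhibitor, a higher number a weaker inhibitor:
compound 1, `COc1cccc2c1ccn2S(=O)(=O)c1ccccc1`: 262 nM
compound 2, `COc1ccc2c(ccn2S(=O)(=O)c2ccccc2)c1`: 127 nM
compound 3, `CN1CCN(c2cccc3c2ccn3S(=O)(=O)c2ccccc2)CC1`: 1 nM

Compound 1 and compound 2 are built from the same atoms joined differently; the difference between the two cores is not broken down here. Their values show compound 2 with the lower number, and that gap lies beyond the usual scatter.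

Compound 3 is compound 1 with 4-methylpiperazin-1-yl in place of methoxy on an aromatic carbon. That single change gave a 260-fold lower number from compound 1 to compound 3 (2.42 log units; beyond the scatter).

Compound 4, `CN1CCN(c2ccc3c(ccn3S(=O)(=O)c3ccccc3)c2)CC1`, is compound 2 with 4-methylpiperazin-1-yl in place of methoxy on an aromatic carbon. The entering and leaving groups are the same as before, but the place is not word for word the same: in compound 3 the new group sits ortho to a fused ring and meta to a fused ring, in compound 4 meta to a fused ring and para to a fused ring, so this is the same kind of change rather than the same change.

Beside a 260-fold lower number from compound 1 to compound 3 (2.42 log units; beyond the scatter), the step of an 85-fold lower number from compound 2 to compound 4 (1.93 log units; beyond the scatter) is expected, resting on that one earlier instance and on the lower start of compound 2. Compound 4 is therefore estimated at 1.5 nM, with a range from 0.3 nM to 8 nM.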

Compound 4, inhibition constant: 27 nM
Compound 4: middle estimate off by 18-fold (1.26 log units), on the low side; measured number above the stated range.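

Putting 4-methylpiperazin-1-yl in place of methoxy lowered the number here too, giving a 4.7-fold lower number from compound 2 to compound 4 (0.67 log units; beyond the scatter). The direction of the change therefore held on both cores, but its size did not carry over: the same change on two cores in this assay, a 260-fold lower number (2.42 log units; beyond the scatter) from compound 1 to compound 3 and a 4.7-fold lower number (0.67 log units; beyond the scatter) from compound 2 to compound 4, 56-fold (1.75 log units) apart, beyond the scatter of two such steps With only these two pairs, the result shows that a large gain on one core cannot simply be assumed on the other, but it does not show why the two steps differ or predict what the change would do on any further core.

The compounds shown leave open whether the smaller step belongs to 4-methylpiperazin-1-yl alone or would also appear with other groups in its place, such as piperazin-1-yl without the methyl or a simple amine like dimethylamino. They also leave open whether the gap between the two cores would remain with a longer chain, such as ethyl, in place of that methyl.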